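Trimming the Ester: From Acetoxy to Free Hydroxyl

This account rests on a few compounds, and the source may have more. Where it says the series, first, only, none or still open, it means among the compounds named here.

Measured so far:
- Compound 1 `COC(=O)/C(=C/Cn1c(-c2ccccc2)ncc(NC(=O)OCc2ccccc2)c1=O)COC(=O)c1ccccc1` gives 1.6 ug/mL in a functional assay on cells (Macrophage cell line, Homo sapiens) for inhibition; on this read-out lower numbers stand for stronger inhibition and higher numbers for weaker inhibition
- Compound 2 `COC(=O)/C(=C/Cn1c(-c2ccccc2)ncc(NC(=O)OCc2ccccc2)c1=O)COC(=O)c1ccc([N+](=O)[O-])cc1` gives 3.6 ug/mL in this assay
- Compound 3 `COC(=O)/C(=C/Cn1c(-c2ccccc2)ncc(NC(=O)OCc2ccccc2)c1=O)COC(C)=O` gives 1.08 ug/mL in this assay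

Among the three measured numbers, compound 3 has the lowest, with compound 1 closest and compound 2 furthest away. The three differ only in the group attached to the carbonyl of the ester on the side chain: a 1.5-fold lower number from compound 1 to compound 3 (0.17 log units; within the scatter), while a 3.3-fold lower number from compound 2 to compound 3 (0.52 log units; beyond the scatter). The ester partner can thus be exchanged with only modest effect.

Compound 4 `COC(=O)/C(=C/Cn1c(-c2ccccc2)ncc(NC(=O)OCc2ccccc2)c1=O)CO` removes that ester entirely: hydrogen in place of acetyl on an oxygen on a saturated carbon. For the measured compounds named here, no measured step does exactly this, but the two steps that reach compound 3 both change the same ester and stay modest, so the side chain appears tolerant of variation at this point. A free hydroxyl is nonetheless a larger departure than swapping one acyl group for another, so a somewhat wider uncertainty is reasonable. The estimate for compound 4 is therefore a value close to that of compound 3, around 1.3 ug/mL with a range from 0.5 ug/mL to 3.5 ug/mL, meaning an expected step of a 1.2-fold higher number from compound 3 to compound 4 (0.08 log units; within the scatter), not clearly beyond the scatter.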

Compound 4, half-maximal inhibitory concentration: 0.78 ug/mL
Beside the measured number, compound 4's estimate is 1.7-fold (0.22 log units) above it, and the stated range covers the measured number.
By their numbers in this assay, from the lowest: compounds 4, 3 and 1 (each within the scatter of the next, the first and the last beyond it); then compound 2.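

Compound 4 shows that this oxygen needs no acyl group to keep its reading in this assay: with the acetyl replaced by a bare hydrogen, the result is a 1.4-fold lower number from compound 3 to compound 4 (0.14 log units; within the scatter) and gives no sign of a gain or a loss. The larger esters do separate from the free hydroxy form, with a 2.1-fold lower number from compound 1 to compound 4 (0.31 log units; beyond the scatter) and a 4.6-fold lower number from compound 2 to compound 4 (0.66 log units; beyond the scatter) both printed as beyond the scatter, the second being the largest step among these compounds. Benzoyl and (4-nitrophenyl)carbonyl on this oxygen therefore go with higher numbers than hydrogen, while acetyl cannot be told apart from it.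

The compounds shown do not tell how a methyl ether, an amine or a carboxylic acid would read at this place on the saturated carbon. Nothing available gives a reason for these differences.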